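Swapping Bromine for Chlorine on a Triazene Ring

The source may report more compounds than this note shows. Statements on the series, on what has been measured and on what is new or still open speak of the compounds shown alone.

Compound 1 `Brc1cccc(/N=N/N2CCCCC2)c1` was tested in an ADME assay on Vero cells (Chlorocebus sabaeus) for cytotoxicity, read by crystal violet staining (on this read-out lower numbers stand for higher toxicity in this test and higher numbers for lower toxicity in this test), where compound 1 gives 85000 nM, the highest of the two plain numbers in this set. Compound 3 `Cc1c(/N=N/c2cccc(C(F)(F)F)c2)ccc(NC[C@@H]2CCCN3CCCC[C@H]23)c1C` gives 80000 nM in this assay, a gap from compound 1 that sits within the usual scatter. For compound 2 `Clc1ccc(/N=N/N2CCCCC2)cc1` this assay reports only a limit, > 100000 nM, as noted in the limit of > 100000 nM in this assay, at which 1 of the 3 values shown sits. Compound 4 `Clc1cccc(/N=N/N2CCCCC2)c1` differs from compound 1 in one place: chloro in place of bromo on an aromatic carbon. Going by the values given here, no measured pair in this set shows what such a swap does in this assay, so the expected step from compound 1 to compound 4 is small, likely none beyond the scatter, if anything toward a higher number. Compound 4 is therefore estimated at 100000 nM, in a range from 50000 nM to 200000 nM, which means an expected step of a 1.2-fold higher number from compound 1 to compound 4 (0.07 log units; within the scatter).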

Compound 4, half-maximal cytotoxic concentration: > 100000 nM
Compound 4 gave a limit, no number (the forecaster's own chance of this, stated with the estimate: 45%); the middle value lies on the limit itself.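

Going by these compounds alone, this pair gives the first one-place comparison in the set: chloro in place of bromo on an aromatic carbon gives an at least 1.1-fold higher number from compound 1 to compound 4 (0.07 log units; that floor lies within the scatter) in this assay. The result for compound 4 is a limit and not a number, so only a floor for the step can be read, and that floor shows no clear change. Limits now make up a larger share of this small set: the limit of > 100000 nM in this assay, at which 2 of the 4 values shown sit.

As far as these compounds go, the true size of the step remains open. So does the outcome with an amine or a carboxylic acid at this aromatic carbon.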